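Urea to amide on the anilide arm of compound 2

The compounds below may be only part of what the source reports. "The series", "measured", "known", "first", "only" and "open" are said of these compounds alone.

Three compounds share one core and differ only at the arm attached to the amide-type nitrogen or at a methoxy group. Compound 1 `COc1cc(-c2nn(-c3cccc(NC(=O)c4cccc(C(F)(F)F)c4)c3)cc2-c2ccncc2)ccc1Cl` gives 2780 nM in a functional assay on A498 cells (Homo sapiens) for inhibition, read by sulforhodamine B assay, with a stated time of 48 h; a lower number here means a stronger inhibitor of growth, a higher number a weaker inhibitor of growth. Compound 2 `COc1cc(-c2nn(-c3cccc(NC(=O)Nc4ccc(Cl)c(Cl)c4)c3)cc2-c2ccncc2)ccc1Cl` gives 4590 nM in this assay, the highest of the three numbers, though its nearest neighbour compound 3 `O=C(Nc1cccc(-n2cc(-c3ccncc3)c(-c3ccc(Cl)c(O)c3)n2)c1)Nc1ccc(Cl)c(Cl)c1` gives 3170 nM, and both of its neighbours sit within the scatter of it. The steps between them are small: a 1.7-fold higher number from compound 1 to compound 2 (0.22 log units; within the scatter) and a 1.4-fold lower number from compound 2 to compound 3 (0.16 log units; within the scatter).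

Compound 4 `COc1cc(-c2nn(-c3cccc(NC(=O)c4ccc(Cl)c(C(F)(F)F)c4)c3)cc2-c2ccncc2)ccc1Cl` is not yet measured. It differs from compound 2 in one place: 4-chloro-3-(trifluoromethyl)phenyl in place of (3,4-dichlorophenyl)amino on a carbonyl carbon. Within the data shown here, this change runs in the opposite sense to the one from compound 1 to compound 2, which replaced 3-(trifluoromethyl)phenyl by (3,4-dichlorophenyl)amino and gave a 1.7-fold higher number from compound 1 to compound 2 (0.22 log units; within the scatter), a step within the scatter; compound 4 carries a 4-chloro-3-(trifluoromethyl)phenyl group on that carbonyl carbon, so it is a close relative of compound 1 rather than of compound 2. Among the measured compounds shown here, no step for the added chlorine alone is available. A modest return toward compound 1 is therefore expected, with no step beyond the scatter: a 1.8-fold lower number from compound 2 to compound 4 (0.25 log units; within the scatter). Compound 4 is estimated at 2600 nM in this assay, with a range from 1200 nM to 5600 nM.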

Compound 4, concentration for total growth inhibition: 22700 nM
Estimate against measurement, compound 4: 8.7-fold (0.94 log units) below, outside the stated range (above it).
By their numbers in this assay, from the lowest: compounds 1, 3 and 2 (each within the scatter of the next); then compound 4.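

Until now, the changes at this carbonyl carbon had stayed within the scatter in this assay, as with a 1.7-fold higher number from compound 1 to compound 2 (0.22 log units; within the scatter), so the position had seemed to accept quite different groups. Among these compounds, compound 4 shows that it does not accept all of them: placing 4-chloro-3-(trifluoromethyl)phenyl on the carbonyl carbon instead of (3,4-dichlorophenyl)amino gives a 4.9-fold higher number from compound 2 to compound 4 (0.69 log units; beyond the scatter), and the single change of chloro in place of hydrogen on an aromatic carbon gives an 8.2-fold higher number from compound 1 to compound 4 (0.91 log units; beyond the scatter), both beyond the scatter. The response to this chloro therefore depends on the group already on that ring, although nothing presented here explains the loss.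

From the compounds shown here alone, it remains open whether the loss is specific to chloro, or whether a fluoro, a methyl or a methoxy group in its place on the 3-(trifluoromethyl)phenyl ring would give a similar step. It is also unknown whether a urea bearing the same 4-chloro-3-(trifluoromethyl)phenyl ring would behave like compound 4, and whether a hydroxyl in place of the methoxy group of compound 4 would leave its number unchanged, as the step to compound 3 did for compound 2.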